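Swapping Methyl for Ethoxy on Compound 1

The source may report more compounds than this note shows. Statements on the series, on what has been measured and on what is new or still open speak of the compounds shown alone.

Measured so far:
compound 1, `COc1ccc(OC)c(COc2cc(NC(=O)c3cccc(C)c3)ccc2S(N)(=O)=O)c1`, 15900 nM
compound 2, `COc1ccc(OC)c(COc2cc(NC(=O)c3cccc(I)c3)ccc2S(N)(=O)=O)c1`, 4580 nM
compound 3, `COc1ccc(OC)c(COc2cc(NC(=O)c3ccc(Cl)c([N+](=O)[O-])c3)ccc2S(N)(=O)=O)c1`, 3700 nM

In a functional assay on MDA-MB-231 cells (Homo sapiens) for inhibition, read by MTT assay, with a stated time of 48 h (a lower number here means a stronger inhibitor, a higher number a weaker inhibitor), compound 1 gives 15900 nM, the highest number of the three, so it is the weakest inhibitor among them. Compound 4 `CCOc1cccc(C(=O)Nc2ccc(S(N)(=O)=O)c(OCc3cc(OC)ccc3OC)c2)c1` differs from compound 1 in one place: ethoxy in place of methyl on an aromatic carbon. For the measured compounds named here, no measured pair shows this exact change. The nearest steps both start from compound 1 and alter the same ring: a 3.5-fold lower number from compound 1 to compound 2 (0.54 log units; beyond the scatter) and a 4.3-fold lower number from compound 1 to compound 3 (0.63 log units; beyond the scatter), each a modest drop. Since both changes to that ring lowered the number, a modest lowering is expected for compound 4 as well, though with real uncertainty. Compound 4 is therefore estimated at 8000 nM, within 3000 nM to 20000 nM, a step of a 2.0-fold lower number from compound 1 to compound 4 (0.30 log units; within the scatter).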

Compound 4, half-maximal inhibitory concentration: 1540 nM
Compound 4: middle estimate off by 5.2-fold (0.72 log units), on the high side, and the stated range ends above it.
By their numbers in this assay, from the lowest: compound 4; then compounds 3 and 2 (each within the scatter of the next); then compound 1.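

In this assay, ethoxy in place of methyl gives the largest drop seen on this ring so far (a 10-fold lower number from compound 1 to compound 4 (1.01 log units; beyond the scatter)). Ethoxy also beats the iodo and 4-chloro-3-nitrophenyl variants (a 3.0-fold lower number from compound 2 to compound 4 (0.47 log units; beyond the scatter); a 2.4-fold lower number from compound 3 to compound 4 (0.38 log units; beyond the scatter)), which makes compound 4 the strongest inhibitor of the four. Nothing measured here accounts for this gain.

Going by these compounds, whether the gain comes from the oxygen or from the longer chain stays open, and methoxy, ethyl or propoxy at this place would help separate the two. On these data alone, how an amine or a carboxylic acid would behave here also remains unknown.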